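The source may report more compounds than this note shows. Statements on the series, on what has been measured and on what is new or still open speak of the compounds shown alone.

In a physicochemical assay for solubility, read by chemiluminescence, measured as kinetic solubility (on this read-out higher numbers stand for higher solubility and lower numbers for lower solubility), the three compounds measured on this shared core all stand at limits rather than numbers. Compound 1 `CC(=O)NCc1cccc(Cn2nc(NS(=O)(=O)c3ccc(Cl)s3)c3ccccc32)c1` gives >= 117 ug/mL, which is a limit. Compound 2 `CC(=O)NCc1cccc(Cn2nc(NS(=O)(=O)c3ccc(Cl)s3)c3c(O)cccc32)c1` gives >= 166 ug/mL, also a limit. Compound 3 `CC(=O)NCc1cccc(Cn2nc(NS(=O)(=O)c3ccc(Cl)s3)c3c(C#N)cccc32)c1` gives >= 155 ug/mL, again a limit. Compound 4 `CC(=O)NCc1cccc(Cn2nc(NS(=O)(=O)c3ccc(Cl)s3)c3c(C(C)O)cccc32)c1` carries 1-hydroxyethyl in place of cyano on an aromatic carbon. The measured steps that bear on this are a step that the two limits leave unreadable from compound 1 to compound 2, a step that the two limits leave unreadable from compound 1 to compound 3 and a step that the two limits leave unreadable from compound 2 to compound 3, and none has a readable size. this assay therefore offers no size to carry over, and no shift beyond the scatter is expected in either direction. The expected change is an at least 1.0-fold lower number from compound 3 to compound 4 (0.01 log units; that floor lies within the scatter). For compound 4 the estimated value is 150 ug/mL, with an expected range from 80 ug/mL to 190 ug/mL.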

Compound 4, solubility: >= 208 ug/mL
Compound 4 was reported as a limit; the forecaster's own chance of this, stated with the estimate: 70%; at least 1.3-fold (0.14 log units) between middle value and limit.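

Going by these compounds alone, compound 1, compound 2, compound 3 and compound 4 all stand at limits in this assay, and no step to compound 4 can be read. The compounds shown leave open whether hydrogen, hydroxy, cyano or 1-hydroxyethyl at this place changes the read-out at all.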